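From isopropyl to fluoro: a tolerance estimate for compound 4

The source may hold more compounds than are shown below. What is called first, only, known or untested is meant among the compounds shown, and "the series" means these compounds.

Measured in an ADME assay on L929 cells (Mus musculus) for cytotoxicity, read by resazurin assay, with a stated time of 96 h; a lower number here means that less compound is tolerated, a higher number that more compound is tolerated:
Compound 1 `NC(=S)N/N=C(/COc1ccc(Br)cc1)c1ccc(Br)cc1`: 22600 nM
Compound 2 `COc1ccc(/C(COc2ccc(Br)cc2)=N\NC(=S)Nc2ccccc2)cc1`: "not determined" (no result reported)
Compound 3 `CC(C)c1ccc(OC/C(=N\NC(N)=S)c2ccc(Br)cc2)cc1`: 24600 nM

The account starts from compound 3, which gives a number (  24600 nM  ) that lies within the usual scatter of the number for compound 1 (  22600 nM  ). Compound 2 offers no number for comparison, so these two values are all that the series provides so far.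

The next compound to be tested is compound 4 (  `NC(=S)N/N=C(\COc1ccc(F)cc1)c1ccc(Br)cc1`  ). It carries fluoro in place of isopropyl on an aromatic carbon, para to a large group (  fluoro in place of isopropyl on an aromatic carbon  ). Going by the values given here, no two measured compounds differ in one place alone, so no measured step shows what such a change does in this assay and the expectation rests on thin ground. With compound 3 at 24600 nM and compound 1 close to it within the scatter, the expectation is for no change beyond the scatter, with no firm direction. The expected shift is small (  a 1.1-fold higher number from compound 3 to compound 4 (0.06 log units; within the scatter)  ). For compound 4 the estimated value is 28000 nM, with an expected range from 13000 nM to 60000 nM.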

Compound 4, half-maximal cytotoxic concentration: 52300 nM
Compound 4: middle estimate off by 1.9-fold (0.27 log units), on the low side; measured number inside the range.
By their numbers in this assay, from the lowest: compounds 1 and 3 (each within the scatter of the next); then compound 4.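

Going by these compounds alone, the exchange of isopropyl for fluoro on an aromatic carbon, para to a large group, brings a 2.1-fold higher number from compound 3 to compound 4 (0.33 log units; beyond the scatter) in this assay, the first step between two compounds that differ in one place. It shows that the number in this assay is not indifferent to the group at this position: replacing three carbon atoms with one fluorine moves it beyond the scatter, towards more compound being tolerated, although the step is only modest in size. No measurement available here accounts for this step, so it stands as an observation on a single pair.

With only this one step, the compounds shown leave open whether the rise comes from the loss of isopropyl or from the arrival of fluoro, and whether the same exchange would give a similar step on a different pair of compounds. They also leave open how an amine, a carboxylic acid or a longer chain at this position would compare with either of these two groups.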